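Replacing a hydroxyphenyl ether with a dimethylphenyl ether

The source may hold more compounds than are shown below. What is called first, only, known or untested is meant among the compounds shown, and "the series" means these compounds.

Compound 1 `COc1ccc(OCC(=O)N2CCN(c3ccc(C(F)(F)F)cc3[C@@H](N)CC(C)C)CC2)cc1` is the starting point of this small series. In an assay on HEK293 cells for displacement of a labelled ligand from Melanocortin receptor 4 (Homo sapiens) (a lower number here means a stronger inhibitor, a higher number a weaker inhibitor), compound 1 gives 3800 nM. Compound 2 `CC(C)C[C@H](N)c1cc(C(F)(F)F)ccc1N1CCN(C(=O)COc2ccc(O)cc2)CC1` differs only in the oxygen substituent on the outer aromatic ring, and in this assay compound 2 gives 4600 nM. The step of a 1.2-fold higher number from compound 1 to compound 2 (0.08 log units; within the scatter) shows that this exchange left the binding essentially unchanged, so compound 2 stands alongside compound 1, the two values lying within the scatter of each other.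

Compound 3 `Cc1ccc(OCC(=O)N2CCN(c3ccc(C(F)(F)F)cc3[C@@H](N)CC(C)C)CC2)c(C)c1` takes the same position in a different direction: 2,4-dimethylphenyl in place of 4-hydroxyphenyl on an oxygen on a saturated carbon. Within the data shown here, the only measured step that bears on this change is a 1.2-fold higher number from compound 1 to compound 2 (0.08 log units; within the scatter), which altered the same outer ring and produced nothing beyond the scatter. Because a 1.2-fold higher number from compound 1 to compound 2 (0.08 log units; within the scatter) was so small, no large shift in this assay is expected for compound 3 either, and the step from compound 2 is estimated as a 1.5-fold lower number from compound 2 to compound 3 (0.19 log units; within the scatter). Compound 3 is therefore expected to give about 3000 nM, within a range from 1000 nM to 9000 nM.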

Compound 3, inhibition constant: 4000 nM
Beside the measured number, compound 3's estimate is 1.3-fold (0.12 log units) below it; measured number inside the range.
By their numbers in this assay, from the lowest: compounds 1, 3 and 2 (each within the scatter of the next).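

Swapping the oxygen substituent on the outer ring was the only earlier test of this position, whereas compound 3 carries a different set of ring substituents, with no oxygen on the ring and no hydrogen-bond donor or acceptor in the group. Even so, this assay gives a 1.2-fold lower number from compound 2 to compound 3 (0.06 log units; within the scatter) and a 1.1-fold higher number from compound 1 to compound 3 (0.02 log units; within the scatter), so the 4-hydroxyphenyl, 4-methoxyphenyl and 2,4-dimethylphenyl compounds all lie within the scatter of one another, and the hydroxyl of compound 2 shows no measurable contribution to binding in this small set. No measurement shown here accounts for this agreement.

Compound 3 carries its two methyl groups together, so the compounds shown cannot say what either methyl does alone, as a 2-methylphenyl or a 4-methylphenyl group would. They also leave open whether a markedly different group in this place, such as an amine or a carboxylic acid on the ring or a cyclohexyl ring in place of the aromatic ring, would move the number beyond the scatter.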